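The source may hold more compounds than are shown below. What is called first, only, known or untested is meant among the compounds shown, and "the series" means these compounds.

Compound 1 `CC(C)(C)C(=O)N1Cc2c(NC(=O)c3cccnc3)n[nH]c2C1(C)C` gives 690 nM
Compound 2 `CN1CCC(C(=O)N2Cc3c(NC(=O)C4CCC4)n[nH]c3C2(C)C)CC1` gives 140 nM

Both numbers come from a functional assay on A2780 cells (Homo sapiens) for antiproliferative activity, read by fluorescence, with a stated time of 72 h; on this read-out lower numbers stand for stronger inhibition and higher numbers for weaker inhibition. With compound 2 at 140 nM and compound 1 at 690 nM, compound 2 holds the lower of the two numbers, and the gap lies beyond the usual scatter of repeated measurements. So far, compound 2 is the stronger inhibitor of the pair. Among the measured compounds shown here, no two measured compounds differ in just one place, so the data give no direct measure of what a single change does.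

The next compound to be tested is compound 3 `CN1CCC(C(=O)N2Cc3c(NC(=O)c4cccs4)n[nH]c3C2(C)C)CC1`. It keeps compound 2 except at one point, with thiophen-2-yl in place of cyclobutyl on a carbonyl carbon. One ring replaces another here, so no step beyond the scatter is expected in this assay, and no direction is favoured. The estimated step of a 1.1-fold higher number from compound 2 to compound 3 (0.03 log units; within the scatter) is expected to stay small. The range is kept wide, since compound 1 at 690 nM shows that numbers in this small set can lie well apart. For compound 3 the estimate is 150 nM with 50 nM to 450 nM as the expected range.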

Compound 3, half-maximal inhibitory concentration: 30 nM
Beside the measured number, compound 3's estimate is 5.0-fold (0.70 log units) above it, outside the stated range (below it).
By their numbers in this assay, from the lowest: compound 3; then compound 2; then compound 1.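

Among the compounds shown here, this is the first single change that can be read directly in this set: in this assay putting thiophen-2-yl in place of cyclobutyl on a carbonyl carbon gives a 4.7-fold lower number from compound 2 to compound 3 (0.67 log units; beyond the scatter) and so a real shift rather than noise. With the rest of compound 2 held fixed, exchanging a four-membered non-aromatic ring of carbon only for a five-membered aromatic ring with one hetero atom is enough to move the number, so the group at this place matters in this assay. Nothing measured on these compounds tells which feature of the new ring accounts for the step, whether its sulfur, its aromatic character or its size.

Compound 1 differs from the other two in more than one place, so it adds nothing direct about this position, and a single pair cannot establish a trend. From the compounds shown here alone, it remains open whether the gain belongs to aromatic rings in general or to thiophen-2-yl in particular, a question that a phenyl ring, a furan-2-yl ring or an open alkyl chain on the same carbonyl carbon could answer.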